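The source may hold more compounds than are shown below. What is called first, only, known or untested is meant among the compounds shown, and "the series" means these compounds.

In a functional assay on PC-3 cells (Homo sapiens) for inhibition, read by MTT assay, with a stated time of 48 h (a higher number here means a weaker inhibitor, a lower number a stronger inhibitor), compound 3 `CCSc1nnc(-c2cc(OC)c(OC)c(OC)c2)n1-c1ccc(N(C)C)cc1` gives 46200 nM. Compound 2 `CCSc1nnc(-c2cc(OC)c(OC)c(OC)c2)n1-c1ccc(OC)cc1` gives 57700 nM in this assay, and the step of a 1.2-fold lower number from compound 2 to compound 3 (0.10 log units; within the scatter) stays within the scatter, so the two cannot be told apart. Compound 1 `COc1ccc(-n2c(S)nnc2-c2cc(OC)c(OC)c(OC)c2)cc1` reaches only a limit of this assay, > 60000 nM. Compound 4 `COc1cc(-c2nnc(SCC(=O)C3CC3)n2-c2ccc(N(C)C)cc2)cc(OC)c1OC` differs from compound 3 by cyclopropylcarbonyl in place of methyl on a saturated chain carbon bound to a sulfur. Among the compounds with values here, the only earlier change on the sulfur chain, ethyl in place of hydrogen, gave an at least 1.0-fold lower number from compound 1 to compound 2 (0.01 log units; that floor lies within the scatter), no movement beyond the scatter; no measured step covers the larger cyclopropylcarbonyl group. Compound 4 is therefore expected to stay close to compound 3, with an estimated step of a 1.2-fold lower number from compound 3 to compound 4 (0.06 log units; within the scatter). The expected value for compound 4 is 40000 nM, between 15000 nM and 100000 nM.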

Compound 4, half-maximal inhibitory concentration: 45900 nM
Compound 4: middle estimate off by 1.1-fold (0.06 log units), on the low side; the range from low to high includes it.
By their numbers in this assay, from the lowest: compounds 4, 3 and 2 (each within the scatter of the next). At a limit, above all of these: compound 1.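

Replacing ethyl with (cyclopropylcarbonyl)methyl on the sulfur brings in a three-membered ring and a carbonyl, and the step is a 1.0-fold lower number from compound 3 to compound 4 (0.00 log units; within the scatter) in this assay. This position therefore accepts a much larger group with no readable change in the number, something the smaller ethyl step could not show. Compound 1 stands at a limit, not at a number: the limit of > 60000 nM in this assay, at which 1 of the 4 values shown sits.

On these data alone, whether an amine or a carboxylic acid on the sulfur chain would move the number beyond the scatter remains open.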